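Shortening the alkoxy chain on a chromone dimer

The source may hold more compounds than are shown below. What is called first, only, known or untested is meant among the compounds shown, and "the series" means these compounds.

Compound 1 `CC(C)CCOc1cccc2occ(Cc3coc4ccccc4c3=O)c(=O)c12` — > 10000 nM
Compound 2 `COc1ccc2c(=O)c(Cc3coc4cccc(OCC5CCCCC5)c4c3=O)coc2c1` — 1440 nM
Compound 3 `O=c1c(CCc2coc3ccccc3c2=O)coc2ccccc12` — > 10000 nM

Of the compounds shown here, three have been tested in a functional assay on NUGC-3 cells (Homo sapiens) for antiproliferative activity, read by XTT assay; on this read-out lower numbers stand for stronger inhibition and higher numbers for weaker inhibition. Compound 1 gives > 10000 nM in this assay, which is a limit of the measurement and not a number. Compound 3 likewise gives > 10000 nM in this assay, again only a limit. Within the data shown here, compound 2 is the one member with a measured number, 1440 nM in this assay. Compound 1 thus stands at the limit of > 10000 nM in this assay, at which 2 of the 3 values shown sit, and nothing within the shown data separates it from compound 3; only compound 2 lies clearly inside the measurable range.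

The unmeasured compound 4 `CC(C)COc1cccc2occ(Cc3coc4ccccc4c3=O)c(=O)c12` differs from compound 1 in one place: isopropyl in place of isobutyl on a saturated chain carbon bound to an oxygen on an aromatic ring. Among the measured compounds shown here, no step between measured compounds involves this kind of change, so its size cannot be read from the data. Because compound 1 sits at the limit of > 10000 nM in this assay, at which 2 of the 3 values shown sit, the expectation for compound 4 is that it stays at that limit as well. Compound 4 is expected to give 15000 nM in this assay, with a range from 5000 nM to 50000 nM. The estimated step is a step that the limit leaves unreadable from compound 1 to compound 4, which is expected to lie within the scatter.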

Compound 4, half-maximal inhibitory concentration: > 10000 nM
Compound 4 gave a limit, no number; the forecaster's own chance of this, stated with the estimate: 75%; the middle value does not contradict the limit.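

No step can be read from compound 1 to compound 4, as both compounds stand at a limit and not at a number: the limit of > 10000 nM in this assay, at which 3 of the 4 values shown sit.

The compounds shown leave open whether isopropyl in place of isobutyl on this chain changes activity at all in this assay, or whether either group would matter on a compound inside the measurable range.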